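Extending the hydroxyurea substituent from ethyl to isopropyl

A few compounds are considered here, and "the series" means these few. Any claim that something is new, unique, unknown or untested is made for them only; others in the source may bear on it.

Of the compounds shown here, three sharing a biaryl core have been measured in a functional assay on IMR-90 cells for antagonist activity at B1 bradykinin receptor (Homo sapiens), read by calcium flux; a lower number here means a stronger inhibitor, a higher number a weaker inhibitor. Compound 1 `Cc1nc(-c2c(F)cc(Cl)cc2-c2cnc([C@@H](C)NC(=O)N(C)O)c(F)c2)no1` gives 1.2 nM. Compound 2 `CN(O)C(=O)NCc1ncc(-c2cc(Cl)cc(F)c2-c2nnn(C)n2)cc1F`, which carries a methyl group on the hydroxylated nitrogen, gives 17 nM. Compound 3 `CCN(O)C(=O)NCc1ncc(-c2cc(Cl)cc(F)c2-c2nnn(C)n2)cc1F`, the ethyl analogue, gives 4.6 nM, placing it second highest of the three, between compound 2 and compound 1. Within the data shown here, the one directly comparable step is a 3.7-fold lower number from compound 2 to compound 3 (0.57 log units; beyond the scatter), a modest gain beyond the scatter when a methyl replaces hydrogen on the chain carbon bound to the amide-type nitrogen.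

Compound 4 `CC(C)N(O)C(=O)NCc1ncc(-c2cc(Cl)cc(F)c2-c2nnn(C)n2)cc1F` takes that chain one carbon further: methyl in place of hydrogen on a saturated chain carbon bound to an amide-type nitrogen and a saturated chain carbon. Among the measured compounds shown here, only the step from compound 2 to compound 3 bears on this change, and a second increment of the same kind need not repeat it. Compound 4 is therefore expected to show a small improvement or none beyond the scatter, a 1.5-fold lower number from compound 3 to compound 4 (0.19 log units; within the scatter). Compound 4 is estimated at 3 nM, within a range of 1.2 nM to 8 nM.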

Compound 4, half-maximal inhibitory concentration: 1 nM
Beside the measured number, compound 4's estimate is 3.0-fold (0.48 log units) above it; the whole stated range lies above it.
By their numbers in this assay, from the lowest: compounds 4 and 1 (each within the scatter of the next); then compound 3; then compound 2.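

In this assay, the gain seen with the first added carbon on the amide-type nitrogen did not level off: going from ethyl to isopropyl gives a 4.6-fold lower number from compound 3 to compound 4 (0.66 log units; beyond the scatter), a second step beyond the scatter after a 3.7-fold lower number from compound 2 to compound 3 (0.57 log units; beyond the scatter). Taken end to end, replacing methyl with isopropyl on this nitrogen gives a 17-fold lower number from compound 2 to compound 4 (1.23 log units; beyond the scatter), a large step, so the number falls at each stage across these three compounds, and none of them goes against that order. Nothing available explains why branching at this saturated chain carbon goes with the lower number.

On these data alone, it remains open whether the trend continues with a tert-butyl group, a cyclopropyl ring or a longer chain on the same nitrogen, or whether it has already reached its end at isopropyl. Also unresolved is whether isopropyl would bring a similar step on the core of compound 1, which carries methyl there.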